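Ethyl in Place of Trifluoromethyl: Metabolic Stability Expected

A few compounds are considered here, and "the series" means these few. Any claim that something is new, unique, unknown or untested is made for them only; others in the source may bear on it.

This account follows three measured esters and one that awaits measurement. Compound 1 `CCc1ccccc1OC(=O)c1coc(-c2ccccc2)n1`, compound 2 `O=C(Oc1ccccc1C(F)(F)F)c1coc(-c2ccccc2)n1` and compound 3 `O=C(OCc1ccccc1C(F)(F)F)c1coc(-c2ccccc2)n1` were all tested in an ADME assay on microsomes from liver (Rattus norvegicus, strain Sprague-Dawley) for metabolic stability, read by LC-MS, with a stated time of 15 min, tested at 20 uM; a lower number here means that less of the compound is left, a higher number that more of the compound is left. In this assay compound 1 gives 8.5%, compound 2 gives 10.7% and compound 3 gives 7.8%. Compounds 1 and 2 differ in one place: ethyl in place of trifluoromethyl on an aromatic carbon. That change brought a number 2.2 percentage points lower from compound 2 to compound 1 (within the scatter), so the two values sit within the scatter of each other.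

Compound 4 `CCc1ccccc1COC(=O)c1coc(-c2ccccc2)n1` has not yet been measured. It stands to compound 3 exactly as compound 1 stands to compound 2: ethyl in place of trifluoromethyl on an aromatic carbon. The surroundings of the change are the same in both pairs, so it is the same change made on a different core. How the core of compound 3 differs from the core of compound 2 is not broken down here.

Because the earlier instance of the change gave a number 2.2 percentage points lower from compound 2 to compound 1 (within the scatter), the step from compound 3 to compound 4 is expected to be of similar size, namely a number 1.8 percentage points lower from compound 3 to compound 4 (within the scatter). Since compound 3 gives 7.8%, compound 4 is expected to give 6% in this assay, with a plausible range from 2% to 14%.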

Compound 4, percent of the compound remaining: 3.2%
Compound 4: middle estimate off by 2.8 percentage points, on the high side; the measured number falls inside the stated range.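

In this assay the same change, ethyl in place of trifluoromethyl on an aromatic carbon, gave a number 4.6 percentage points lower from compound 3 to compound 4 (within the scatter), so compound 3 and compound 4 stand within the scatter of each other. On the two cores shown, the change carries over in the sense that neither instance leaves the scatter, and the two steps cannot be told apart: the same change on two cores in this assay, a number 2.2 percentage points lower (within the scatter) from compound 2 to compound 1 and a number 4.6 percentage points lower (within the scatter) from compound 3 to compound 4, 2.4 percentage points apart, within the scatter of two such steps This does not show that the change has a fixed size or even a fixed direction, since steps this small cannot establish either one, and two cores cannot speak for the whole series.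

The compounds shown carry only ethyl or trifluoromethyl at this place, and all of them are esters with the same phenyl group on the far side of the shared core. Going by these compounds, what an amine, a carboxylic acid or a longer chain at this place would give in this assay remains open, as does whether the change would behave in the same way with an amide in place of the ester.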